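Rearranging the tertiary alcohol of a plumbagin-type ester

The source may report more compounds than this note shows. Statements on the series, on what has been measured and on what is new or still open speak of the compounds shown alone.

Measured compounds:
Compound 1, `CCCCC(O)CC(=O)O[C@H](CC=C(C)C)C1=CC(=O)c2c(O)ccc(O)c2C1=O`, 72200 nM
Compound 2, `CC(C)=CC[C@@H](OC(=O)CC(C)(O)C(C)C)C1=CC(=O)c2c(O)ccc(O)c2C1=O`, 27700 nM

Two esters sharing the same core have been tested in a functional assay on HeLa cells (Homo sapiens) for cytotoxicity, read by MTT assay; on this read-out lower numbers stand for stronger inhibition and higher numbers for weaker inhibition. In this assay compound 1 gives 72200 nM, and compound 2 gives 27700 nM. For the measured compounds named here, compound 2 therefore stands at the lower of the two numbers, with compound 1 as its only neighbour; the step of a 2.6-fold lower number from compound 1 to compound 2 (0.42 log units; beyond the scatter) separates them.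

Compound 3, `CCC(O)(CC)CC(=O)O[C@H](CC=C(C)C)C1=CC(=O)c2c(O)ccc(O)c2C1=O`, is the next compound and has not yet been measured. It differs from compound 2 in one place: 1-ethyl-1-hydroxypropyl in place of 1-hydroxy-1,2-dimethylpropyl on a saturated chain carbon bound to a carbonyl carbon. Going by the values given here, the only measured step, a 2.6-fold lower number from compound 1 to compound 2 (0.42 log units; beyond the scatter), concerns a different change, in which a secondary alcohol with a linear chain was replaced by a tertiary one; it offers no direct guide to moving the same atoms around within a tertiary alcohol. Among the compounds with values here, with no closer precedent, a step within the usual scatter is expected for this assay.

Compound 3 is therefore estimated at 30000 nM, with a likely range from 12000 nM to 75000 nM. The expected step from compound 2 is a 1.1-fold higher number from compound 2 to compound 3 (0.03 log units; within the scatter).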

Compound 3, half-maximal inhibitory concentration: 52000 nM
Beside the measured number, compound 3's estimate is 1.7-fold (0.24 log units) below it; the range from low to high includes it.
By their numbers in this assay, from the lowest: compounds 2, 3 and 1 (each within the scatter of the next, the first and the last beyond it).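

In this assay, rearranging the same atoms from 1-hydroxy-1,2-dimethylpropyl to 1-ethyl-1-hydroxypropyl gives a 1.9-fold higher number from compound 2 to compound 3 (0.27 log units; within the scatter), while the change from 1-hydroxypentyl to 1-ethyl-1-hydroxypropyl gives a 1.4-fold lower number from compound 1 to compound 3 (0.14 log units; within the scatter). Compound 3 therefore cannot be told apart from either of the other two, even though the step of a 2.6-fold lower number from compound 1 to compound 2 (0.42 log units; beyond the scatter) lies beyond the scatter. A tertiary alcohol on a saturated chain carbon bound to a carbonyl carbon is thus not enough on its own to separate a compound from the secondary alcohol of compound 1, as compound 3 carries one and stays within the scatter of compound 1, and no available data explain these numbers.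

Going by these compounds, all three compounds keep a hydroxyl in this group, so it remains open whether replacing that hydroxyl with an amine or a carboxylic acid would move the number in this assay. On these data alone, it is also open whether a longer chain in place of the two ethyl groups, or a ring in that place, would give a step beyond the scatter from compound 3.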